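Chalcone-pyrazole series: dichloro to dimethoxy on the carbonyl

A few compounds are considered here, and "the series" means these few. Any claim that something is new, unique, unknown or untested is made for them only; others in the source may bear on it.

Three compounds of the series carry a measurement in a functional assay on OVCAR-8 cells (Homo sapiens) for cytotoxicity, read by sulforhodamine B assay, with a stated time of 48 h, tested at 100 uM; a lower number here means a stronger effect, a higher number a weaker effect of the compound at the concentration tested. Compound 1 `COc1ccc(-c2cc(/C=C/C(=O)c3ccc(OC)c(OC)c3)[nH]n2)cc1` gives -66%, compound 2 `COc1cc(-c2cc(/C=C/C(=O)c3ccc(Cl)c(Cl)c3)[nH]n2)cc(OC)c1OC` gives -36%, and compound 3 `COc1ccc(-c2cc(/C=C/C(=O)c3cc(OC)c(OC)c(OC)c3)[nH]n2)cc1OC` gives -84%. Compound 2 stands highest of the three; its nearest neighbour is compound 1, and compound 3 lies furthest from it. Among the compounds with values here, no single-change step between measured compounds is available. The new compound 4 `COc1ccc(C(=O)/C=C/c2cc(-c3cc(OC)c(OC)c(OC)c3)n[nH]2)cc1OC` is related to compound 2 by 3,4-dimethoxyphenyl in place of 3,4-dichlorophenyl on a carbonyl carbon. The two compounds bearing a methoxylated ring on the carbonyl carbon, compound 1 and compound 3, both show lower numbers than compound 2. The step from compound 2 to compound 4 is therefore expected to go downward, beyond the scatter, at a number 34 percentage points lower from compound 2 to compound 4 (beyond the scatter). Compound 4 is estimated at -70%, within -90% to -45%.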

Compound 4, a percentage reported as activity, at one concentration (the size of the read-out at that concentration, not a potency): -96%
Compound 4: the middle estimate sits 26 percentage points above what was measured, and the stated range ends above it.
By their numbers in this assay, from the lowest: compound 4; then compound 3; then compound 1; then compound 2.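

On a carbonyl carbon, 3,4-dimethoxyphenyl in place of 3,4-dichlorophenyl gives the series its first single-change reading in this assay, with a number 60 percentage points lower from compound 2 to compound 4 (beyond the scatter) as a large step. The earlier compounds shown here differed in more than one place, whereas here the rest of the structure stays fixed and the step belongs to this position alone. Nothing at hand bears on why the step is this large.

Where a ring carrying an amine or a carboxylic acid would fall at this carbonyl carbon remains open. So does whether the step holds with other substituents on the rest of the core.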